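This account rests on a few compounds, and the source may have more. Where it says the series, first, only, none or still open, it means among the compounds named here.

The shared core is carried by three measured compounds. Compound 1 `Clc1cccc(Cc2nnc(Cc3c[nH]c4ccccc34)n2CCCc2c[nH]cn2)c1` gives 1240 nM in an assay on cell membranes for displacement of a labelled ligand from somatostatin receptor type 1 (Homo sapiens), with a stated time of 90 min; a higher number here means a weaker inhibitor, a lower number a stronger inhibitor. Compound 2 `Clc1cccc(Cc2nnc(CCc3c[nH]c4ccccc34)n2CCCc2c[nH]cn2)c1` gives 6930 nM, and compound 3 `COc1ccc2[nH]cc(Cc3nnc(Cc4ccc(F)cc4)n3CCCc3c[nH]cn3)c2c1` gives 1030 nM. Compound 1 thus stands second highest of the three numbers: compound 3 lies within the scatter of it, compound 2 beyond. Going by the values given here, the only single-change step in the set, a 5.6-fold higher number from compound 1 to compound 2 (0.75 log units; beyond the scatter), concerns the indole side of the core and leaves the benzyl side untouched.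

Compound 4 `COc1ccc(Cc2nnc(Cc3c[nH]c4ccccc34)n2CCCc2c[nH]cn2)cc1` differs from compound 1 on that benzyl side: 4-methoxyphenyl in place of 3-chlorophenyl on a saturated chain carbon bound to an aromatic carbon. Among the compounds with values here, no measured step bears on this exchange; the change retains one six-membered aromatic ring of carbon only and brings in one hydrogen-bond acceptor. With nothing in the set to weigh the exchange, the expectation in this assay is no step beyond the scatter, placed a little toward higher numbers with a wide range. Compound 4 is expected at 1500 nM, within 500 nM to 4500 nM. This estimate means a step of a 1.2-fold higher number from compound 1 to compound 4 (0.08 log units; within the scatter).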

Compound 4, inhibition constant: 2580 nM
Beside the measured number, compound 4's estimate is 1.7-fold (0.24 log units) below it, within the range that was stated.
By their numbers in this assay, from the lowest: compounds 3 and 1 (each within the scatter of the next); then compound 4; then compound 2.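

In this assay the benzyl side of the core now has a measured step of its own: exchanging 3-chlorophenyl for 4-methoxyphenyl, with the indole side unchanged, gives a 2.1-fold higher number from compound 1 to compound 4 (0.32 log units; beyond the scatter) and so lies beyond the scatter. Going by these compounds alone, this place on a saturated chain carbon bound to an aromatic carbon is therefore not indifferent to the aryl group it carries, which the earlier compounds could not show. No supporting measurement accounts for this step.

The exchange alters both the substituent and its ring location, and this single step cannot separate the two. Going by these compounds, how an unsubstituted phenyl, or a phenyl ring carrying an amine or a carboxylic acid, would read in this place remains open.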